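Replacing the Ester of Compound 1 with a Methylisoxazole

The source may hold more compounds than are shown below. What is called first, only, known or untested is meant among the compounds shown, and "the series" means these compounds.

Measured so far in a functional assay on Jurkat cells for inhibition of nuclear factor NF-kappa-B complex (Homo sapiens); on this read-out lower numbers stand for stronger inhibition and higher numbers for weaker inhibition:
compound 1 `CCOC(=O)c1cnc(-c2cccs2)nc1NN1C(=O)C=C(C)C1=O` gives 20 nM
compound 2 `CCOC(=O)c1cnc(Sc2ccccc2)nc1NN1C(=O)C=C(C)C1=O` gives 1000 nM

For the measured compounds named here, compound 1 holds the lowest of the two numbers; its only neighbour is compound 2, and the step of a 50-fold higher number from compound 1 to compound 2 (1.70 log units; beyond the scatter) separates them. Compound 3 `CC1=CC(=O)N(Nc2nc(-c3cccs3)ncc2-c2cc(C)no2)C1=O` has not been measured. It differs from compound 1 in one place: 3-methyl-1,2-oxazol-5-yl in place of ethoxycarbonyl on an aromatic carbon. Going by the values given here, the single measured step concerns a different site of the shared core, the carbon carrying thiophen-2-yl, and no measured pair speaks to an exchange of the ethoxycarbonyl group. The expectation for compound 3 therefore rests on compound 1 alone and must be kept wide. Compound 3 is expected to give 60 nM, with a range from 10 nM to 400 nM. This estimate corresponds to an expected step of a 3.0-fold higher number from compound 1 to compound 3 (0.48 log units; beyond the scatter), a range that also admits no change beyond the scatter.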

Compound 3, half-maximal inhibitory concentration: 300 nM
Compound 3: the middle estimate sits 5.0-fold (0.70 log units) below what was measured; measured number inside the range.
By their numbers in this assay, from the lowest: compound 1; then compound 3; then compound 2.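

The carbon carrying ethoxycarbonyl proved sensitive to exchange in this assay and the step is a 15-fold higher number from compound 1 to compound 3 (1.18 log units; beyond the scatter) even though 3-methyl-1,2-oxazol-5-yl brings the same count of hydrogen-bond donors and acceptors as the group it replaces and no net charge. Matching those counts therefore did not hold the number of compound 1, and this carbon joins the one carrying thiophen-2-yl as a second place on the shared core where a single exchange gives a large step. No evidence at hand bears on what lies behind this step.

From the compounds shown here alone, it remains open whether the higher number goes with the entering ring or its methyl group, which a plain 1,2-oxazol-5-yl could separate. Going by these compounds, it is equally open how a carboxylic acid, a primary amide or a nitrile would read at this carbon.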